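Swapping the Substituent on the Ring Nitrogen

This account rests on a few compounds, and the source may have more. Where it says the series, first, only, none or still open, it means among the compounds named here.

Compound 1 `CCCCCC(=O)c1ccc(OCCCN2CCN(C(=O)OC)CC2)cc1` gives 12000 nM in an assay on isolated protein for binding affinity to histamine H2 receptor (Homo sapiens); on this read-out higher numbers stand for weaker inhibition and lower numbers for stronger inhibition.
Compound 2 `CCCCCC(=O)c1ccc(OCCCN2CCN(C(=O)OCC(C)C)CC2)cc1` gives 3720 nM in this assay.
Compound 3 `CCCCCC(=O)c1ccc(OCCCN2CCN(S(=O)(=O)c3ccc(C#N)cc3)CC2)cc1` gives 12300 nM in this assay.

Compound 3 holds the highest number of the three; its gap to compound 1 lies within the scatter, and only a 3.3-fold higher number from compound 2 to compound 3 (0.52 log units; beyond the scatter) marks a clear difference. Compound 4 `CCCCCC(=O)c1ccc(OCCCN2CCN(C(=O)C(C)C)CC2)cc1` arises from compound 3 by isopropylcarbonyl in place of (4-cyanophenyl)sulfonyl on an amine nitrogen in a ring. Going by the values given here, two measured steps bear on this: a 1.0-fold higher number from compound 1 to compound 3 (0.01 log units; within the scatter) and a 3.3-fold higher number from compound 2 to compound 3 (0.52 log units; beyond the scatter), each exchanging a carbonyl-bearing group for the sulfonyl group. Reversing that exchange with another carbonyl-bearing group should move the number down, between no change and a modest drop. A modest lowering is therefore expected for compound 4, a 2.1-fold lower number from compound 3 to compound 4 (0.31 log units; beyond the scatter). Compound 4 is estimated at 6000 nM, with a range from 2000 nM to 18000 nM.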

Compound 4, inhibition constant: 29500 nM
Compound 4: middle estimate off by 4.9-fold (0.69 log units), on the low side, outside the stated range (above it).
By their numbers in this assay, from the lowest: compound 2; then compounds 1 and 3 (each within the scatter of the next); then compound 4.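

A carbonyl group on the ring nitrogen does not by itself lower the number, since isopropylcarbonyl in place of (4-cyanophenyl)sulfonyl gives a 2.4-fold higher number from compound 3 to compound 4 (0.38 log units; beyond the scatter) and places compound 4 above the sulfonyl compound. The group on the carbonyl carbon matters: isopropyl in place of methoxy gives a 2.5-fold higher number from compound 1 to compound 4 (0.39 log units; beyond the scatter) and isopropyl in place of isobutoxy gives a 7.9-fold higher number from compound 2 to compound 4 (0.90 log units; beyond the scatter) in the same direction. No measurement shown here accounts for these steps.

From the compounds shown here alone, whether an amine or a longer carbon chain on the carbonyl carbon would track with the alkoxy compounds or with compound 4 remains open.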